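This account rests on a few compounds, and the source may have more. Where it says the series, first, only, none or still open, it means among the compounds named here.

Measured compounds: compound 1, `CCCCCCC#Cc1cc2cn(COCCO)c(=O)nc2o1`, gives > 200000 nM in a functional assay on HEL cells (Homo sapiens), read by microscopy; on this read-out higher numbers stand for lower toxicity in this test and lower numbers for higher toxicity in this test; compound 2, `CCCCCCCc1cc2cn(COCCO)c(=O)nc2o1`, gives 400000 nM; compound 3, `CCCCCCCCCc1cc2cn(COCCO)c(=O)nc2o1`, gives >= 16000 nM.

Going by the values given here, compound 2 stands as the only number among the three; the other two are limits. For compound 1 the value > 200000 nM is a limit of the test, not a number. For compound 3 the value >= 16000 nM is likewise a limit. The step that the limit leaves unreadable from compound 2 to compound 3 therefore cannot be read. Compound 4, `CCCCC#Cc1cc2cn(COCCO)c(=O)nc2o1`, differs from compound 2 by hex-1-yn-1-yl in place of heptyl on an aromatic carbon. Among the compounds with values here, no measured step bears on this change; compound 1 and compound 2 show only a limit beside a number. In this assay compound 4 is expected near 300000 nM, within 100000 nM to 1000000 nM, so that the step of a 1.3-fold lower number from compound 2 to compound 4 (0.12 log units; within the scatter) is expected to stay within the scatter.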

Compound 4, minimum cytotoxic concentration: > 100000 nM
Compound 4: only a limit was reported; the forecaster's own chance of this, stated with the estimate: 70%; the middle value lies beyond the limit too.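

Compound 4 gives > 100000 nM, a limit and not a number, so its steps from compound 1 and compound 2 cannot be read. The compounds shown leave open how hex-1-yn-1-yl and heptyl compare in this assay.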